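This account rests on a few compounds, and the source may have more. Where it says the series, first, only, none or still open, it means among the compounds named here.

In an ADME assay on Raji cells (Homo sapiens) for cytotoxicity, read by luminescence, with a stated time of 72 h (a higher number here means that more compound is needed for the effect, a lower number that less compound is needed), compound 3 `CCOC(=O)c1c(-c2cccc(OC)c2)[nH]c2cc(OC)c(OC)cc2c1=O` gives > 21500 nM, which is a limit of the assay and not a number. Compound 2 `CCOC(=O)c1c(-c2cccc(-c3ccccc3)c2)[nH]c2cc(OC)c(OC)cc2c1=O` gives > 21500 nM, also a limit. Compound 1 `CCOC(=O)c1c(-c2cccc(Oc3ccccc3)c2)[nH]c2cc(OC)ccc2c1=O` gives > 21500 nM, again a limit. For the measured compounds named here, compound 3 therefore has no numerical position of its own, and no compound in this small set can be ranked against another.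

The next compound is compound 4 `CCOC(=O)c1c(-c2cccc(Oc3ccccc3)c2)[nH]c2cc(OC)c(OC)cc2c1=O`, and the change leading to it is phenyl in place of methyl on an oxygen on an aromatic ring. In words, this is phenyl in place of methyl on an oxygen on an aromatic ring, so methoxy becomes phenoxy.

Going by the values given here, only one measured step bears on this change: a step that the two limits leave unreadable from compound 2 to compound 3. That step, methoxy in place of phenyl on an aromatic carbon, also involves these two groups, but its size cannot be read and it gives no direction.

The whole basis for the expectation is the limit of > 21500 nM in this assay, at which 3 of the 3 values shown sit. Among the compounds with values here, no step of readable size is therefore expected in this assay, in either direction. The estimated change is a number no higher from compound 3 to compound 4 (the limit leaves the size open). The expected value for compound 4 is 21500 nM, with an estimated range from 9000 nM to 30000 nM, and it is expected most probably to be reported as a limit again.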

Compound 4, half-maximal effective concentration: > 21500 nM
Compound 4: a limit, no number; the forecaster's own chance of this, stated with the estimate: 85%; the middle value lies on the limit itself.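

In this assay compound 4 gives > 21500 nM, which is a limit of the assay and not a number. No new step can be read between compound 4 and compound 1, compound 2 or compound 3, as all four stand only as limits. The compounds shown leave open whether any change on the shared core would give a measurable value in this assay.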